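The compounds below may be only part of what the source reports. "The series", "measured", "known", "first", "only" and "open" are said of these compounds alone.

Measured compounds:
compound 1, `CN(C)CCn1c(=O)sc2cc(NS(=O)(=O)c3ccc4ccccc4c3)ccc21`: 22%
compound 2, `O=c1sc2cc(NS(=O)(=O)c3ccc4ccccc4c3)ccc2n1CCN1CCCC1`: 0%
compound 3, `CN(C)CCn1c(=O)sc2cc(S(=O)(=O)Nc3ccccc3)ccc21`: 21%

In an assay on HEK293 cells for displacement of a labelled ligand from 5-hydroxytryptamine receptor 6 (Homo sapiens), read by radioligand binding, with a stated time of 60 min, tested at 100 nM (on this read-out higher numbers stand for more inhibition at the one concentration tested (going by the name of the read-out) and lower numbers for less inhibition), compound 1 gives 22%, while compound 2 gives 0%. The two differ by one change, (pyrrolidin-1-yl in place of dimethylamino on a saturated chain carbon, two bonds along the chain from an aromatic nitrogen), and that change made a step of a number 22 percentage points lower from compound 1 to compound 2 (beyond the scatter). Compound 3 gives 21%, which lies within the scatter of compound 1 and beyond the scatter of compound 2. The difference between the core of compound 3 and the core of compound 1 is not broken down here.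

Compound 4, `O=c1sc2cc(S(=O)(=O)Nc3ccccc3)ccc2n1CCN1CCCC1`, has not been measured. Going by the values given here, it differs from compound 3 by pyrrolidin-1-yl in place of dimethylamino on a saturated chain carbon, two bonds along the chain from an aromatic nitrogen, the same change as the one from compound 1 to compound 2. Because that change gave a number 22 percentage points lower from compound 1 to compound 2 (beyond the scatter), a step of similar size is expected from compound 3 to compound 4, a number 19 percentage points lower from compound 3 to compound 4 (beyond the scatter). Compound 4 is therefore estimated at 2%, expected to fall between -10% and 14%.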

Compound 4, a percentage reported as inhibition, at one concentration (the size of the read-out at that concentration, not a potency): 37%
For compound 4 the middle estimate is 35 percentage points below the measured one, and the stated range ends below it.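

In this assay the change from dimethylamino to pyrrolidin-1-yl gave a number 16 percentage points higher from compound 3 to compound 4 (beyond the scatter) and so did not carry over from the core of compound 1 in either direction or size. The two cores respond differently to the same change: the same change on two cores in this assay, a number 22 percentage points lower (beyond the scatter) from compound 1 to compound 2 and a number 16 percentage points higher (beyond the scatter) from compound 3 to compound 4, 38 percentage points apart, beyond the scatter of two such steps. Going by these compounds alone, this shows that the step cannot be transferred between these two cores, but with only two pairs it does not show which part of the cores sets the difference, or how the change would behave on any other core.

The compounds shown leave open how a piperidine or morpholine ring in place of these amines would read on either core. They also leave open what a longer chain carrying the same amines would do.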